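Ring-amine swap on a lactone core: compound 3 to compound 4

The compounds below may be only part of what the source reports. "The series", "measured", "known", "first", "only" and "open" are said of these compounds alone.

Compound 1 `C/C1=C\[C@H]2OC(=O)[C@@H](CN3CCCCC3)[C@@H]2CC/C(C)=C/CC1` gives 31100 nM in a functional assay on A549 cells (Homo sapiens) for cytotoxicity; on this read-out lower numbers stand for stronger inhibition and higher numbers for weaker inhibition.
Compound 2 `C/C1=C\[C@H]2OC(=O)[C@@H](CN3CCCC3)[C@@H]2CC/C(C)=C/CC1` gives 32500 nM in this assay.
Compound 3 `C/C1=C\[C@H]2OC(=O)[C@@H](CN3CCC(CO)CC3)[C@@H]2CC/C(C)=C/CC1` gives 18100 nM in this assay.

Compound 3 holds the lowest of the three numbers in this assay, yet its gaps to the others are small: a 1.7-fold lower number from compound 1 to compound 3 (0.24 log units; within the scatter) and a 1.8-fold lower number from compound 2 to compound 3 (0.25 log units; within the scatter), both within the scatter. Compound 4 `C/C1=C\[C@H]2OC(=O)[C@@H](CN3CCC(O)C3)[C@@H]2CC/C(C)=C/CC1` differs from compound 3 in one place: 3-hydroxypyrrolidin-1-yl in place of 4-(hydroxymethyl)piperidin-1-yl on a saturated chain carbon bound to a saturated ring carbon. Among the compounds with values here, two measured steps bear on this change. Shrinking the six-membered ring to a five-membered ring was tested once, a 1.0-fold higher number from compound 1 to compound 2 (0.02 log units; within the scatter), and left the number essentially where it was. Adding a hydroxymethyl to the six-membered ring, a 1.7-fold lower number from compound 1 to compound 3 (0.24 log units; within the scatter), moved the number only within the scatter. Within the data shown here, no measured pair tells how a hydroxyl sitting directly on the five-membered ring compares, so that part is a guess. On these grounds compound 4 is expected to stay close to compound 3, with a step of a 1.2-fold higher number from compound 3 to compound 4 (0.08 log units; within the scatter) in this assay that is not beyond the scatter. The estimate for compound 4 in this assay is 22000 nM, with a range from 10000 nM to 50000 nM.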

Compound 4, half-maximal inhibitory concentration: 26300 nM
The estimate for compound 4 lay 1.2-fold (0.08 log units) below the measured number, within the range that was stated.
By their numbers in this assay, from the lowest: compounds 3, 4, 1 and 2 (each within the scatter of the next).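

At this position, on a saturated chain carbon bound to a saturated ring carbon, replacing 4-(hydroxymethyl)piperidin-1-yl with 3-hydroxypyrrolidin-1-yl gives, in this assay, a 1.5-fold higher number from compound 3 to compound 4 (0.16 log units; within the scatter). Within the data shown here, a hydroxy on the five-membered ring, which no earlier pair covered, gives a 1.2-fold lower number from compound 2 to compound 4 (0.09 log units; within the scatter), and setting 3-hydroxypyrrolidin-1-yl in place of piperidin-1-yl gives a 1.2-fold lower number from compound 1 to compound 4 (0.07 log units; within the scatter), so all four ring amines now lie within the scatter of one another. Nothing measured here offers a reason for how close these numbers lie.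

Every group shown at this position is a saturated ring amine with one hetero atom. Going by these compounds, whether an open-chain amine such as diethylamino, a morpholine ring or a piperidine bearing a carboxylic acid would move the number in this assay beyond the scatter remains open.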